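A Small Ring Swap: Phenyl to Thiophen-3-yl

This account rests on a few compounds, and the source may have more. Where it says the series, first, only, none or still open, it means among the compounds named here.

Measured compounds:
compound 1 `O=C(Nc1ccc2scnc2c1)C1CCCN(Cc2ccc(F)c(F)c2)C1` – > 20000 nM
compound 2 `O=C(Nc1ccc(-c2cscn2)cc1)C1CCCN(Cc2cccnc2)C1` – > 20000 nM
compound 3 `O=C(Nc1ccc(-c2ccccc2)cc1)C1CCCN(Cc2ccc(F)c(F)c2)C1` – 5000 nM

Among the measured compounds shown here, in a functional assay on A-375 cells (Homo sapiens) for activation, with a stated time of 3 days (a higher number here means that more compound is needed for the effect, a lower number that less compound is needed), compound 3 gives 5000 nM, the only plain number among the three results. Compound 1 gives only a limit of the assay, > 20000 nM. Compound 2 likewise gives only a limit, > 20000 nM. The picture is shaped by the limit of > 20000 nM in this assay, at which 2 of the 3 values shown sit, so compound 3 stands alone as the measured reference.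

Compound 4 `O=C(Nc1ccc(-c2ccsc2)cc1)C1CCCN(Cc2ccc(F)c(F)c2)C1` is not yet measured in this assay. It differs from compound 3 in one place: thiophen-3-yl in place of phenyl on an aromatic carbon. For the measured compounds named here, no step between measured compounds shows what such a ring swap does here. With nothing to point the other way, the step is expected to stay within the usual scatter, no change at the digits printed from compound 3 to compound 4 (within the scatter). Compound 4 is therefore estimated at 5000 nM, with a range from 1500 nM to 20000 nM.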

Compound 4, half-maximal effective concentration: 1930 nM
For compound 4 the middle estimate is 2.6-fold (0.41 log units) above the measured one; low and high end bracket the measured number.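

In this assay, putting thiophen-3-yl in place of phenyl on the aromatic carbon para to a large group gives a 2.6-fold lower number from compound 3 to compound 4 (0.41 log units; beyond the scatter). This is the only step shown between two plain numbers, and it shows that this position accepts a five-membered aromatic ring with one sulfur, with less compound needed for the effect. Nothing shown gives a reason for this step. From the compounds shown here alone, whether furan-3-yl or thiophen-2-yl at the same place would do as well remains open, as does the effect of an amine on the thiophene ring.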